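The source may hold more compounds than are shown below. What is called first, only, known or untested is meant among the compounds shown, and "the series" means these compounds.

Compound 2, with the structure `Cc1ccc(CN2CCC(CCN(Cc3ccc(-c4ccc(F)cc4)cc3)C(=O)NC(C)C)CC2)cc1`, gives 383 nM in an in vitro functional assay on HEK293 cells for antagonist activity at melanin-concentrating hormone receptor 1 (Homo sapiens), read by GTPgammaS binding, with a stated time of 45 min (a lower number here means a stronger inhibitor, a higher number a weaker inhibitor), the higher of the two numbers recorded so far. Compound 1, with the structure `Cc1ccc(CN2CCC(NC(=O)NCc3ccc(-c4ccc(F)cc4)cc3)CC2)cc1`, gives 198 nM in this assay, a gap that lies within the scatter. Compound 3, with the structure `Cc1ccc(CN2CCC(CCN(Cc3ccc(-c4cccc(C#N)c4)cc3)C(=O)NC(C)C)CC2)cc1`, differs from compound 2 by 3-cyanophenyl in place of 4-fluorophenyl on an aromatic carbon. Within the data shown here, no measured pair shows what this change does, so only a modest shift, in either direction or none beyond the scatter, is expected. The step from compound 2 to compound 3 is estimated at a 1.0-fold higher number from compound 2 to compound 3 (0.02 log units; within the scatter). Compound 3 is therefore expected to give 400 nM, within 150 nM to 1200 nM.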

Compound 3, antagonist equilibrium constant: 1010 nM
For compound 3 the middle estimate is 2.5-fold (0.40 log units) below the measured one; low and high end bracket the measured number.
By their numbers in this assay, from the lowest: compounds 1 and 2 (each within the scatter of the next); then compound 3.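

In this assay, 3-cyanophenyl in place of 4-fluorophenyl gives a 2.6-fold higher number from compound 2 to compound 3 (0.42 log units; beyond the scatter) and so makes a weaker inhibitor. This shows that the group at this position, para to a large group, can change the result by more than the scatter. Nothing measured here gives the reason for this loss.

Still open, as far as these compounds go, is whether the nitrile itself or its place on the ring matters, and a 4-cyanophenyl or 3-fluorophenyl group would separate the two. Also open, from the compounds shown here alone, is how an amine or a carboxylic acid on that ring would compare.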